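Benzyl-to-phenethyl change on an aminotriazine series

A few compounds are considered here, and "the series" means these few. Any claim that something is new, unique, unknown or untested is made for them only; others in the source may bear on it.

Compound 1 `Nc1nc(NCc2ccc(F)cc2)nc(-c2c(F)cccc2CO)n1` in a functional assay on cells for positive allosteric modulation of G-protein coupled receptor 68 (Homo sapiens), read by a luciferase reporter and cAMP accumulation, with a stated time of 30 min, at pH 6.8 and pH 8.3, in the presence of a further agent that is not named here (on this read-out higher numbers stand for higher potency (the scale is a negative logarithm) and lower numbers for lower potency), gives 4.45
Compound 2 `Cc1cccc(CNc2nc(N)nc(-c3c(F)cccc3CO)n2)c1` in this assay gives 4.44

Compound 2 stands lowest of the two numbers, and its neighbour compound 1 lies within the scatter of it; the step of a number 0.01 log units lower from compound 1 to compound 2 (within the scatter) bears out that closeness. Compound 3 `Nc1nc(NCCCc2ccccc2)nc(-c2c(F)cccc2CO)n1` is the unmeasured member. It differs from compound 2 by phenethyl in place of 3-methylphenyl on a saturated chain carbon bound to a nitrogen on an aromatic ring. Within the data shown here, no measured step covers this kind of change; the one step known, a swap of one aryl group for another, moved nothing beyond the scatter. Compound 3 is therefore expected to sit close to compound 2, with a step of a number 0.01 log units higher from compound 2 to compound 3 (within the scatter). The estimate for compound 3 is 4.45, ranging from 4 to 4.9.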

Compound 3, negative logarithm of the antagonist equilibrium constant: 4.47
Compound 3: the middle estimate sits 0.02 log units below what was measured; the range from low to high includes it.
By their numbers in this assay, from the lowest: compounds 2, 1 and 3 (each within the scatter of the next).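

Phenethyl in place of 3-methylphenyl gives a number 0.03 log units higher from compound 2 to compound 3 (within the scatter) in this assay, and phenethyl in place of 4-fluorophenyl gives a number 0.02 log units higher from compound 1 to compound 3 (within the scatter). This place, on a saturated chain carbon bound to a nitrogen on an aromatic ring, had so far shown only one aryl group swapped for another, and it now also takes phenethyl with no shift beyond the scatter. Nothing at hand accounts for this flatness. Going by these compounds, whether an amine, a carboxylic acid or a longer chain at this place would move the number beyond the scatter stays open.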